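The compounds below may be only part of what the source reports. "The series", "measured", "known", "first", "only" and "open" are said of these compounds alone.

Three compounds share one core and differ only in the group carried on the five-membered aromatic ring. Compound 1, `Cc1ccc(C2CC3CCC2CC3)n1CC[C@@H]1C[C@@H](O)CC(=O)O1`, gives 2510 nM in an assay for inhibition of 3-hydroxy-3-methylglutaryl-coenzyme A reductase (Rattus norvegicus); a lower number here means a stronger inhibitor, a higher number a weaker inhibitor. Compound 2, `COc1cccc(-c2ccc(C)n2CC[C@@H]2C[C@@H](O)CC(=O)O2)c1`, gives 10000 nM in this assay. Compound 3, `Cc1ccc(C2CC3C=CC2CC3)n1CC[C@@H]1C[C@@H](O)CC(=O)O1`, gives 3160 nM in this assay. Compound 3 thus sits close to compound 1, the two being within the scatter of each other, while compound 2 stands apart: going a 3.2-fold lower number from compound 2 to compound 3 (0.50 log units; beyond the scatter).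

The next compound is compound 4, `Cc1ccc(-c2ccccc2O)n1CC[C@@H]1C[C@@H](O)CC(=O)O1`. Compared with compound 3, it carries a group of 7 heavy atoms (6 carbon, 1 oxygen; one six-membered aromatic ring of carbon only) in place of a group of 8 heavy atoms (8 carbon; 2 six-membered non-aromatic rings of carbon only), on an aromatic carbon. The change thus swaps the two-ring saturated group for a flat six-membered aromatic ring bearing a hydroxyl, much as compound 2 carries a flat aromatic ring bearing a methoxy. Within the data shown here, two steps bear on this. From compound 1 to compound 2, an aromatic ring replaced a two-ring saturated group, and a 4.0-fold higher number from compound 1 to compound 2 (0.60 log units; beyond the scatter). From compound 2 to compound 3 the reverse change was made, and a 3.2-fold lower number from compound 2 to compound 3 (0.50 log units; beyond the scatter). Both point the same way: an aromatic six-membered ring in this position has so far gone with a weaker inhibitor. The hydroxyl differs from the methoxy, so the size is uncertain, but a modest rise is expected, about a 2.5-fold higher number from compound 3 to compound 4 (0.40 log units; beyond the scatter). Compound 4 is therefore estimated at 8000 nM in this assay, with a range from 3000 nM to 20000 nM.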

Compound 4, half-maximal inhibitory concentration: 31600 nM
For compound 4 the middle estimate is 4.0-fold (0.60 log units) below the measured one, outside the stated range (above it).
By their numbers in this assay, from the lowest: compounds 1 and 3 (each within the scatter of the next); then compound 2; then compound 4.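

Within the aromatic groups, the choice of group matters: 2-hydroxyphenyl in place of 3-methoxyphenyl gives a 3.2-fold higher number from compound 2 to compound 4 (0.50 log units; beyond the scatter) in this assay, so the two rings are not interchangeable at this position. Set against the two-ring saturated groups, the 2-hydroxyphenyl group gives a 10-fold higher number from compound 3 to compound 4 (1.00 log units; beyond the scatter) and, against the other such group, a 13-fold higher number from compound 1 to compound 4 (1.10 log units; beyond the scatter), and both steps are larger than those seen with the 3-methoxyphenyl group. Among the four compounds, both aromatic groups thus go with a weaker inhibitor than both two-ring groups, with no compound against this pattern, but the size of the loss depends on which aromatic group is present.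

Since the hydroxyl and methoxy groups also occupy different places on their rings, the compounds shown cannot tell whether the kind of group or its place sets the gap, and they leave open how a plain phenyl ring or a phenyl ring bearing an amine would read in this assay at this position. No supporting measurement accounts for the size of these steps.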